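Two Acylhydrazones Measured, a Third Halogen Swap Awaited

A few compounds are considered here, and "the series" means these few. Any claim that something is new, unique, unknown or untested is made for them only; others in the source may bear on it.

Measured so far:
compound 1, `Cc1nnc(SCC(=O)N/N=c2/scc(-c3ccc(Cl)cc3)n2-c2ccccc2)s1`, which gives 253 ug/mL
compound 2, `O=C(CSc1nnnn1-c1ccccc1)N/N=c1/scc(-c2ccc(F)cc2)n1-c1ccccc1`, which gives 207 ug/mL

Both compounds were tested in an ADME assay on NIH3T3 cells (Mus musculus) for cytotoxicity, read by MTT assay, with a stated time of 24 h; a lower number here means a stronger inhibitor, a higher number a weaker inhibitor. Compound 1 gives 253 ug/mL and compound 2 gives 207 ug/mL. For the measured compounds named here, compound 2 is one of only two compounds with a number here, and its number sits within the usual scatter of that of compound 1, so the two cannot be told apart on these data.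

Compound 3, `O=C(CSc1nnnn1-c1ccccc1)N/N=c1/scc(-c2ccc(Cl)cc2)n1-c1ccccc1`, has not yet been measured. It differs from compound 2 in one place: chloro in place of fluoro on an aromatic carbon. The same halogen, chloro, is also present in compound 1, whose number is close to that of compound 2. Going by the values given here, no step between two measured compounds has been worked out, so there is no measured change to lean on. Compound 3 is therefore expected to show no shift beyond the scatter in this assay, and its estimated value is 220 ug/mL, within a range from 120 ug/mL to 400 ug/mL, which corresponds to an expected step of a 1.1-fold higher number from compound 2 to compound 3 (0.03 log units; within the scatter).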

Compound 3, half-maximal inhibitory concentration: 313 ug/mL
For compound 3 the middle estimate is 1.4-fold (0.15 log units) below the measured one, and the stated range covers the measured number.
By their numbers in this assay, from the lowest: compounds 2, 1 and 3 (each within the scatter of the next).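

In this assay, the change from 4-fluorophenyl to 4-chlorophenyl now has a measured size, a 1.5-fold higher number from compound 2 to compound 3 (0.18 log units; within the scatter), so at this place on the ring the two halogens cannot be told apart. For the compounds shown here, the group on the sulfur can also be compared for the first time: 1-phenyl-1H-tetrazol-5-yl in place of 5-methyl-1,3,4-thiadiazol-2-yl gives a 1.2-fold higher number from compound 1 to compound 3 (0.09 log units; within the scatter), so these two ring groups cannot be told apart here either. No measured evidence is available to explain either step.

The compounds shown leave open whether an amine or a carboxylic acid in place of the halogen would move the number beyond the scatter. They also leave open whether a simple longer chain on the sulfur, in place of either ring group, would do so.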